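Ring Size at the Amide Carbonyl: Cyclopentyl to Methylcyclohexyl

The source may report more compounds than this note shows. Statements on the series, on what has been measured and on what is new or still open speak of the compounds shown alone.

Compound 1 `CC1CC(C(=O)N2CCc3nc(C#Cc4ccccc4)sc3C2)C1` gives 81 nM in an assay on HEK293 cells for positive allosteric modulation of metabotropic glutamate receptor 5 (Homo sapiens), read by FLIPR, with a stated time of 1 h; on this read-out higher numbers stand for an effect only at larger amounts of compound and lower numbers for an effect already at smaller amounts.
Compound 2 `O=C(C1CCCC1)N1CCc2nc(C#Cc3ccccc3)sc2C1` gives 19 nM in this assay.

Going by the values given here, compound 2 stands at the lower of the two numbers in this assay; the one measured step, a 4.3-fold lower number from compound 1 to compound 2 (0.63 log units; beyond the scatter), sets it apart from compound 1. Compound 3 `CC1CCC(C(=O)N2CCc3nc(C#Cc4ccccc4)sc3C2)CC1` carries 4-methylcyclohexyl in place of cyclopentyl on a carbonyl carbon. Among the compounds with values here, only the step of a 4.3-fold lower number from compound 1 to compound 2 (0.63 log units; beyond the scatter) bears on this change: there the ring on the carbonyl carbon gained one member and the number fell. Whether a further, larger ring continues that is not shown by these two compounds. Compound 3 is therefore expected to give about 25 nM, within 8 nM to 80 nM, an expected step of a 1.3-fold higher number from compound 2 to compound 3 (0.12 log units; within the scatter) that stays within the scatter.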

Compound 3, half-maximal effective concentration: 190 nM
The estimate for compound 3 lay 7.6-fold (0.88 log units) below the measured number, and the stated range ends below it.
By their numbers in this assay, from the lowest: compound 2; then compound 1; then compound 3.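

In this assay the place on the carbonyl carbon does not simply reward a larger ring: 4-methylcyclohexyl in place of cyclopentyl gives a 10-fold higher number from compound 2 to compound 3 (1.00 log units; beyond the scatter). The number also ends higher than with 3-methylcyclobutyl, with a 2.3-fold higher number from compound 1 to compound 3 (0.37 log units; beyond the scatter), so across these three compounds the cyclopentyl of compound 2 gives the lowest number and the order does not follow ring size. Nothing available here explains this result. Still open, going by these compounds, is how plain cyclohexyl would stand, which would separate ring size from the methyl group, and how an open chain such as isobutyl would fare at this carbonyl carbon.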